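Ring carbon to ring nitrogen: what compound 4 may show

This account rests on a few compounds, and the source may have more. Where it says the series, first, only, none or still open, it means among the compounds named here.

Compound 1, `O=C(Nc1ccc(-n2ncc3c(F)cccc32)cc1)Nc1ccc(Cl)c(C(F)(F)F)c1`, gives 8200 nM in a functional assay on HT-29 cells (Homo sapiens) for cytotoxicity, read by MTT assay, with a stated time of 72 h; on this read-out higher numbers stand for weaker inhibition and lower numbers for stronger inhibition.
Compound 2, `Cc1cccc2c1cnn2-c1ccc(NC(=O)Nc2ccc(Cl)c(C(F)(F)F)c2)cc1`, gives 32000 nM in this assay.
Compound 3, `O=C(Nc1ccc(-n2ncc3ccccc32)cc1)Nc1ccc(Cl)c(C(F)(F)F)c1`, gives 18200 nM in this assay.

Among these three numbers compound 3 stands second highest. Its nearest neighbour is compound 2, with a 1.8-fold lower number from compound 2 to compound 3 (0.25 log units; within the scatter), a gap that stays within the scatter. Its furthest neighbour is compound 1, with a 2.2-fold higher number from compound 1 to compound 3 (0.35 log units; beyond the scatter), a gap beyond the scatter.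

Compound 4, `O=C(Nc1ccc(-n2ncc3cnccc32)cc1)Nc1ccc(Cl)c(C(F)(F)F)c1`, differs from compound 3 by a group of 9 heavy atoms (6 carbon, 3 nitrogen; one five-membered aromatic ring with 2 hetero atoms, one six-membered aromatic ring with 1 hetero atom) in place of a group of 9 heavy atoms (7 carbon, 2 nitrogen; one five-membered aromatic ring with 2 hetero atoms, one six-membered aromatic ring of carbon only), on an aromatic carbon. Going by the values given here, none of the measured steps alters a ring atom; the two steps that touch the same ring system only exchange small groups on an aromatic carbon. From compound 1 to compound 2 the exchange of fluoro for methyl gave a 3.9-fold higher number from compound 1 to compound 2 (0.59 log units; beyond the scatter), and from compound 1 to compound 3 the exchange of fluoro for hydrogen gave a 2.2-fold higher number from compound 1 to compound 3 (0.35 log units; beyond the scatter). Both are modest, and neither speaks directly to a ring nitrogen. The account therefore expects no step beyond the scatter, with a wide allowance for the unfamiliar change: the expected step is a 1.0-fold lower number from compound 3 to compound 4 (0.00 log units; within the scatter). For compound 4 the estimated value in this assay is 18000 nM, with a range from 6000 nM to 55000 nM.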

Compound 4, half-maximal inhibitory concentration: 10500 nM
Estimate against measurement, compound 4: 1.7-fold (0.23 log units) above; measured number inside the range.
By their numbers in this assay, from the lowest: compounds 1, 4, 3 and 2 (each within the scatter of the next, the first and the last beyond it).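

In this assay, the ring nitrogen in the six-membered ring of compound 4 is the only change shown that alters a ring atom rather than a small group on an aromatic carbon, and it gives a 1.7-fold lower number from compound 3 to compound 4 (0.24 log units; within the scatter) in the measured number. The same group set against the fluoro compound gives a 1.3-fold higher number from compound 1 to compound 4 (0.11 log units; within the scatter) so compound 4 lies within the scatter of both compound 1 and compound 3, even though those two stand apart by a 2.2-fold higher number from compound 1 to compound 3 (0.35 log units; beyond the scatter) and beyond the scatter. Only the comparison with the methyl compound clears the scatter, with a 3.0-fold lower number from compound 2 to compound 4 (0.48 log units; beyond the scatter) and that step is modest, so this exchange of a ring carbon for a ring nitrogen is tolerated in this read-out but yields no clear separation from the unsubstituted or fluoro compounds.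

The compounds shown leave open how an amine or a methoxy group on the same ring, or a ring nitrogen elsewhere in that six-membered ring, would compare. No measurement here accounts for the result.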